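From pentylamino to isopropylamino at a cytotoxicity limit

This account rests on a few compounds, and the source may have more. Where it says the series, first, only, none or still open, it means among the compounds named here.

Three compounds that share one core and differ in the chain on a nitrogen on an aromatic ring set the scene. In an ADME assay on MT4 cells (Homo sapiens) for cytotoxicity, read by MTT assay, with a stated time of 5 days (on this read-out higher numbers stand for lower toxicity in this test and lower numbers for higher toxicity in this test), compound 1 `CNc1cc(Oc2c(OC)cc3cc(C#N)ccc3c2OC)nc(Nc2ccc(C#N)cc2)n1` gives 239000 nM as a plain number. Compound 2 `CCNc1cc(Oc2c(OC)cc3cc(C#N)ccc3c2OC)nc(Nc2ccc(C#N)cc2)n1` gives > 125000 nM and this is a limit of the assay. Compound 3 `CCCCCNc1cc(Oc2c(OC)cc3cc(C#N)ccc3c2OC)nc(Nc2ccc(C#N)cc2)n1` gives > 125000 nM and this too is a limit, not a number. Compound 3 therefore has no exact place on the scale and stands at the limit of > 125000 nM in this assay, at which 2 of the 3 values shown sit, and nothing finer can be said of it.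

The step to compound 4 `COc1cc2cc(C#N)ccc2c(OC)c1Oc1cc(NC(C)C)nc(Nc2ccc(C#N)cc2)n1` puts isopropyl in place of pentyl on a nitrogen on an aromatic ring. The measured steps that bear on this change are the chain steps, and none has a readable size: there is a step that the limit leaves unreadable from compound 1 to compound 2 and a step that the limit leaves unreadable from compound 1 to compound 3 and also a step that the two limits leave unreadable from compound 2 to compound 3 among them. No direction can be drawn from them, so no change beyond the scatter is expected. The expected move is a step that the limit leaves unreadable from compound 3 to compound 4 and it is only an estimate. For the measured compounds named here, compound 1 with 239000 nM supplies the sole plain number to lean on. For compound 4 the estimate is 160000 nM with an expected range from 80000 nM to 290000 nM in this assay and a reading that is only a limit seems likely.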

Compound 4, half-maximal cytotoxic concentration: > 125000 nM
Compound 4: a limit, no number; the forecaster's own chance of this, stated with the estimate: 65%; the middle value does not contradict the limit.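

In this assay compound 4 gives only a limit, so its steps to compound 1, compound 2 and compound 3 cannot be read, and it sits where most of these compounds sit: the limit of > 125000 nM in this assay, at which 3 of the 4 values shown sit. The compounds shown leave open whether the chain on the nitrogen moves this read-out at all, with compound 1 the only plain number.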